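The source may report more compounds than this note shows. Statements on the series, on what has been measured and on what is new or still open speak of the compounds shown alone.

Compound 1 `O=C(CCc1cccc2c1B(O)OC2)Nc1ccc(Br)cc1` gives 9200 nM
Compound 2 `O=C(CCc1cccc2c1B(O)OC2)Nc1ccc(I)cc1` gives 51000 nM

Both numbers come from a functional assay on SK-OV-3 cells (Homo sapiens) for antiproliferative activity, read by MTT assay, with a stated time of 72 h; a lower number here means a stronger inhibitor, a higher number a weaker inhibitor. Of the two, the number for compound 2 is the higher, which makes it the weaker inhibitor of this pair. Within the data shown here, the only measured step is a 5.5-fold higher number from compound 1 to compound 2 (0.74 log units; beyond the scatter), a modest change made by putting iodo in place of bromo on an aromatic carbon.

The next compound is compound 3 `CC(C)(C)c1ccc(NC(=O)CCc2cccc3c2B(O)OC3)cc1`, which carries tert-butyl in place of iodo on an aromatic carbon. The counted difference is tert-butyl in place of iodo on an aromatic carbon.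

Among the measured compounds shown here, the single measured step shows that a change at this place can move the number by a modest amount. It links two halogens, however, and offers no direct guide to tert-butyl. With compound 2 at 51000 nM, the top of the small measured range, a modest move toward a lower number in this assay seems the more likely outcome, though the direction remains uncertain. The expected size is a 2.6-fold lower number from compound 2 to compound 3 (0.41 log units; beyond the scatter). For compound 3 the estimated value is 20000 nM, with an expected range from 6000 nM to 70000 nM.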

Compound 3, half-maximal inhibitory concentration: 4200 nM
Estimate against measurement, compound 3: 4.8-fold (0.68 log units) above, outside the stated range (below it).
By their numbers in this assay, from the lowest: compound 3; then compound 1; then compound 2.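

Until now, this place on the aromatic ring had been seen to respond only to a swap between two halogens. Replacing a halogen with tert-butyl shows a larger effect, with a 12-fold lower number from compound 2 to compound 3 (1.08 log units; beyond the scatter) in this assay, which is the largest step among the three compounds. The step against the bromo compound is smaller but still clear, at a 2.2-fold lower number from compound 1 to compound 3 (0.34 log units; beyond the scatter), so compound 3 is the strongest inhibitor of the three, and a group built only of carbon and hydrogen is accepted here at least as well as either halogen. Nothing available explains why the number moves in this way.

As far as these compounds go, with only bromo, iodo and tert-butyl at this place, it remains open whether the lower number belongs to tert-butyl alone or would also appear with other groups, such as methyl, an amine or a carboxylic acid. From the compounds shown here alone, all three compounds also share the same core and the same chain leading to the amide, so it is unknown whether this order would hold with a longer chain.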